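Swapping Chlorine for Fluorine on an Inactive Ketone

The compounds below may be only part of what the source reports. "The series", "measured", "known", "first", "only" and "open" are said of these compounds alone.

Three compounds share one core, a double-bonded chain joining a carbonyl to a second aromatic ring, and differ only in the groups on their two ends. In a functional assay on IGROV-1 cells (Homo sapiens) for inhibition, read by sulforhodamine B assay, with a stated time of 48 h (a lower number here means a stronger inhibitor of growth, a higher number a weaker inhibitor of growth), compound 1 `COc1ccc(-c2cc(/C=C/C(=O)c3ccc(OC)c(OC)c3)[nH]n2)cc1` gives 3650 nM and compound 3 `COc1ccc(-c2cc(/C=C/C(=O)c3cc(OC)c(OC)c(OC)c3)[nH]n2)cc1OC` gives 8610 nM. Compound 2 `COc1cc(-c2cc(/C=C/C(=O)c3ccc(Cl)c(Cl)c3)[nH]n2)cc(OC)c1OC` is the exception: in this assay it reaches only a limit of the assay, > 100000 nM, so no number is known for it, a point recorded in the limit of > 100000 nM in this assay, at which 1 of the 3 values shown sits. Compound 2 therefore sits at the weak end of everything measured here, while compound 1 and compound 3 give real numbers.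

Compound 4 `COc1cc(-c2cc(/C=C/C(=O)c3ccc(F)c(F)c3)[nH]n2)cc(OC)c1OC` differs from compound 2 in one place: 3,4-difluorophenyl in place of 3,4-dichlorophenyl on a carbonyl carbon. For the measured compounds named here, no step between two measured compounds tells how such a change acts in this assay, so the expectation rests only on the three values above. Compound 2 is held at a limit, and the change keeps a halogen pair on the same ring, so the step from compound 2 to compound 4 in this assay is expected to be small, at most modest, in the direction of a stronger inhibitor, expressed as an at least 1.6-fold lower number from compound 2 to compound 4 (0.22 log units; that floor lies within the scatter). Compound 4 is estimated at 60000 nM in this assay, with a range from 15000 nM to 150000 nM.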

Compound 4, concentration for total growth inhibition: 87000 nM
Estimate against measurement, compound 4: 1.5-fold (0.16 log units) below; measured number inside the range.
By their numbers in this assay, from the lowest: compound 1; then compound 3; then compound 4. At a limit, above all of these: compound 2.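

In this assay, compound 4 gives 87000 nM, the only exact number shown for a compound with a halogen pair on the ring attached to the carbonyl carbon. Putting 3,4-difluorophenyl in place of 3,4-dichlorophenyl at this position gives an at least 1.1-fold lower number from compound 2 to compound 4 (0.06 log units; that floor lies within the scatter), so the swap is not shown to make a real difference, although the true step could be larger than this floor. The size of the step remains unknown because compound 2 has a limit rather than a number: the limit of > 100000 nM in this assay, at which 1 of the 4 values shown sits.

On these data alone, it remains open whether an amine or a carboxylic acid on this ring, in place of the two halogens, would give a lower number in this assay. Compound 1 and compound 3 each differ from compound 4 in more than one place, so the printed values cannot show how the fluorine pair on its own compares with the methoxy groups on those compounds.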